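The compounds below may be only part of what the source reports. "The series", "measured", "known", "first", "only" and "open" are said of these compounds alone.

Working notes on the series.

Compound 1 `CCOC(=O)/C(O)=C/C(=O)c1cn(Cc2ccc(F)cc2)c2ccc(OCc3ccc(F)cc3)cc2c1=O` is the reference point. In an ADME assay on TZM cells (Homo sapiens) for cytotoxicity, read by WST assay, with a stated time of 3 days (on this read-out higher numbers stand for lower toxicity in this test and lower numbers for higher toxicity in this test), compound 1 gives > 1000000 nM, which is a limit of the assay and not a number. Going by the values given here, compound 2 `O=C(O)/C(O)=C/C(=O)c1cn(Cc2ccc(F)cc2)c2ccc(OCc3ccc(F)cc3)cc2c1=O` is the only other member measured so far; in this assay compound 2 gives > 1000000 nM, again a limit. Among the compounds with values here, the single measured step, a step that the two limits leave unreadable from compound 1 to compound 2, therefore cannot be read, since the limit of > 1000000 nM in this assay, at which 2 of the 2 values shown sit, holds both values. Compound 1 thus stands at the limit, with no numeric placing on the scale and one further limit alongside it.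

Compound 3 `CCOC(=O)/C=C/c1ccc2c(c1)c(=O)c(C(=O)/C=C(\O)C(=O)OCC)cn2Cc1ccc(F)cc1` has not yet been measured in this assay. It differs from compound 1 as follows: 2-(ethoxycarbonyl)ethenyl in place of (4-fluorobenzyl)oxy on an aromatic carbon. Within the data shown here, no measured step bears on this change; the only step known, from compound 1 to compound 2, is unreadable, so there is no basis for expecting a step beyond the scatter in either direction. The expectation is that compound 3 sits at or near the limit, as compound 1 does with > 1000000 nM, so the expected step of a number no higher from compound 1 to compound 3 (the limit leaves the size open) is taken as none. The estimate for compound 3 in this assay is 1000000 nM, within 300000 nM to 3000000 nM.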

Compound 3, half-maximal cytotoxic concentration: > 1000000 nM
Compound 3: only a limit was reported; the forecaster's own chance of this, stated with the estimate: 70%; the middle value sits exactly at the limit.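

In this assay compound 3 gives > 1000000 nM, which is a limit and not a number. No step from compound 1 to compound 3 can be read, as both compounds rest on the same limit: the limit of > 1000000 nM in this assay, at which 3 of the 3 values shown sit.

The compounds shown leave open whether any replacement on the shared core brings the half-maximal cytotoxic concentration to a readable number.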